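From 4-nitrobenzyl to pentyl in the series

The compounds below may be only part of what the source reports. "The series", "measured", "known", "first", "only" and "open" are said of these compounds alone.

In a functional assay on DU-145 cells (Homo sapiens) for antiproliferative activity, read by MTT assay (on this read-out lower numbers stand for stronger inhibition and higher numbers for weaker inhibition), compound 1 (`CC1(C)CCc2c(ccc(C(=O)/C=C/c3ccc(OCc4cn(-c5ccc(Cl)cc5)nn4)cc3)c2O)O1`) is reported as "not active" (no number reported) without a number. Among the compounds with values here, compound 2 (`CC1(C)CCc2c(ccc(C(=O)/C=C/c3ccc(OCc4cn(Cc5ccc([N+](=O)[O-])cc5)nn4)cc3)c2O)O1`) gives 29900 nM as the only number so far, so it cannot yet be ranked against another value. Compound 3 (`CCCCCn1cc(COc2ccc(/C=C/C(=O)c3ccc4c(c3O)CCC(C)(C)O4)cc2)nn1`) differs from compound 2 by butyl in place of 4-nitrophenyl on a saturated chain carbon bound to an aromatic nitrogen on the shared core, which also reads as 4-nitrobenzyl to pentyl. Within the data shown here, no measured step shows what such a change does. The expected change is none beyond the scatter, in neither direction, and the estimated 1.0-fold higher number from compound 2 to compound 3 (0.00 log units; within the scatter) is small. A report without a number, as for compound 1, remains possible. Compound 3 is expected at 30000 nM with 10000 nM to 80000 nM as the estimated range.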

Compound 3, half-maximal inhibitory concentration: "not active" (no number reported)
The entry for compound 3 holds no number; the estimate stays without a comparison.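

Within the data shown here, compound 3 carries no number, so no step from compound 2 can be read. The compounds shown leave open how the change from 4-nitrobenzyl to pentyl acts in this assay, and no available evidence bears on this result.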